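Swapping a Ring on Compound 1: Permeability Outlook

The source may hold more compounds than are shown below. What is called first, only, known or untested is meant among the compounds shown, and "the series" means these compounds.

Compound 1 `Cc1noc(C)c1CN(C1Cc2cc(C#N)ccc2N(Cc2cncn2C)C1)S(=O)(=O)c1ccccn1` gives 8 10^-6 cm/s in an ADME assay on Caco-2 cells (Homo sapiens) for permeability, in the apical to basolateral direction (a higher number here means that the compound crosses the layer faster, a lower number that the compound crosses the layer more slowly), the higher of the two numbers in hand. Compound 2 `Cn1cnc(S(=O)(=O)N(CCn2cccc2)C2Cc3cc(C#N)ccc3N(Cc3cncn3C)C2)c1` gives 0.3 10^-6 cm/s in this assay, a far lower number. Compound 3 `CC(C)S(=O)(=O)N1CCC(CN(C2Cc3cc(C#N)ccc3N(Cc3cncn3C)C2)S(=O)(=O)c2ccccn2)CC1` is not yet measured; it differs from compound 1 in one place (1-(isopropylsulfonyl)piperidin-4-yl in place of 3,5-dimethyl-1,2-oxazol-4-yl on a saturated chain carbon bound to a sulfonamide nitrogen), so the group that enters is larger and carries a sulfonyl on its ring nitrogen. The step of a 4.0-fold lower number from compound 1 to compound 3 (0.60 log units; beyond the scatter) is expected to be a drop beyond the usual scatter. Compound 3 is therefore estimated to give 2 10^-6 cm/s, most likely between 0.5 10^-6 cm/s and 6 10^-6 cm/s.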

Compound 3, apparent permeability: 0.1 10^-6 cm/s
Compound 3: middle estimate off by 20-fold (1.30 log units), on the high side; measured number below the stated range.
By their numbers in this assay, from the lowest: compound 3; then compound 2; then compound 1.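

On a saturated chain carbon bound to a sulfonamide nitrogen, putting 1-(isopropylsulfonyl)piperidin-4-yl in place of 3,5-dimethyl-1,2-oxazol-4-yl gives an 80-fold lower number from compound 1 to compound 3 (1.90 log units; beyond the scatter) in this assay and so shows that this place is highly sensitive to the group it carries. The two groups have equal counts of hydrogen-bond donors and acceptors and no net charge, so these counts do not separate them. Nothing in hand bears on the cause of this drop. On these data alone, it remains open where a plain piperidin-4-yl without the isopropylsulfonyl group, or a phenyl ring, would fall in this assay.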